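From dimethylcarbamoyl to diethylcarbamoyl on a shared core

A few compounds are considered here, and "the series" means these few. Any claim that something is new, unique, unknown or untested is made for them only; others in the source may bear on it.

Values in a functional assay on U-937 cells (Homo sapiens) (on this read-out higher numbers stand for weaker inhibition and lower numbers for stronger inhibition), for each compound:
Compound 1 `COc1cc(C(=O)NS(=O)(=O)c2ccccc2C)ccc1Cc1cn(C=O)c2ccc(NC(=O)OC3CCCC3)cc12` gives 0.6 nM
Compound 2 `COc1cc(C(=O)NS(=O)(=O)c2ccccc2C)ccc1Cc1cn(C(=O)N(C)C)c2ccc(NC(=O)OC3CCCC3)cc12` gives 1 nM
Compound 3 `CCN(CC)C(=O)n1cc(Cc2ccc(C(=O)NS(=O)(=O)c3ccccc3C)cc2OC)c2cc(NC(=O)OC3CCCC3)ccc21` is not yet measured

Compound 2 (1 nM) cannot be told apart from compound 1 (0.6 nM). Compound 3 differs from compound 2 in one group (diethylamino in place of dimethylamino on a carbonyl carbon), with diethylamino in place of dimethylamino on a carbonyl carbon. Among the measured compounds shown here, the only measured step bearing on this, dimethylamino in place of hydrogen at that same carbon (a 1.7-fold higher number from compound 1 to compound 2 (0.22 log units; within the scatter)), stayed within the scatter, so no step beyond the scatter is expected in this assay. The expected step is small (a 1.5-fold higher number from compound 2 to compound 3 (0.18 log units; within the scatter)). The value expected for compound 3 is 1.5 nM (estimated range 0.5 nM to 4 nM).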

Compound 3, half-maximal inhibitory concentration: 0.8 nM
Compound 3: middle estimate off by 1.9-fold (0.27 log units), on the high side, within the range that was stated.
By their numbers in this assay, from the lowest: compounds 1, 3 and 2 (each within the scatter of the next).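

In this assay, putting diethylamino in place of dimethylamino on the carbonyl carbon gives a 1.3-fold lower number from compound 2 to compound 3 (0.10 log units; within the scatter), and diethylamino in place of hydrogen at that carbon gives a 1.3-fold higher number from compound 1 to compound 3 (0.12 log units; within the scatter). Both steps lie within the scatter, so hydrogen, dimethylamino and diethylamino cannot be told apart at this position on this read-out. Nothing available explains this result.

Still open, on these data alone, is whether a longer chain such as dipropylamino, or a ring amine such as pyrrolidine, on this carbonyl carbon would also stay within the scatter. As far as these compounds go, a carboxylic acid on the end of such a chain is equally open.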